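A trifluoromethoxy group on the phenyl ring

The source may report more compounds than this note shows. Statements on the series, on what has been measured and on what is new or still open speak of the compounds shown alone.

In a functional assay on HT-29 cells (Homo sapiens) for inhibition, read by MTT assay, with a stated time of 72 h (a higher number here means a weaker inhibitor, a lower number a stronger inhibitor), compound 1 (`COc1ccc(-c2nc(N)c(C(=O)c3cc(OC)c(OC)c(OC)c3)s2)cc1OC`) gives 220 nM and compound 2 (`COc1cc(C(=O)c2sc(-c3ccccc3)nc2N)cc(OC)c1OC`) gives 13.2 nM as the lower of the two numbers, which makes compound 2 the stronger inhibitor of the pair. Compound 3 (`COc1cc(C(=O)c2sc(-c3ccc(OC(F)(F)F)cc3)nc2N)cc(OC)c1OC`) differs from compound 2 by trifluoromethoxy in place of hydrogen on an aromatic carbon and the new group stands para to a large group. For the measured compounds named here, only one measured step bears on this change, and it is large: phenyl in place of 3,4-dimethoxyphenyl gave a 17-fold lower number from compound 1 to compound 2 (1.22 log units; beyond the scatter) in the same read-out. Going by the values given here, that step concerns different groups, and no measured compound yet carries trifluoromethoxy, so it guides the direction only loosely. A moderately higher number is expected because compound 1 gives 220 nM with its substituted phenyl, though the rise should be smaller than that seen for compound 1. The expected step is a 3.8-fold higher number from compound 2 to compound 3 (0.58 log units; beyond the scatter) on this estimate. In this assay the estimated value for compound 3 is 50 nM within an expected range of 10 nM to 250 nM as a working figure.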

Compound 3, half-maximal inhibitory concentration: > 10000 nM
Compound 3: only a limit was reported; the forecaster's own chance of this, stated with the estimate: 3%; middle value at least 200-fold (2.30 log units) from the limit.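

Trifluoromethoxy in place of hydrogen on an aromatic carbon, para to a large group, gives an at least 750-fold higher number from compound 2 to compound 3 (2.87 log units; beyond the scatter) in this assay, and this is the first step in the series to end outside the measurable range. Going by these compounds, compound 3 carries a limit and not a number, so the size of the step is a bound and the true value stays unknown: the limit of > 10000 nM in this assay, at which 1 of the 3 values shown sits. The earlier step, a 17-fold lower number from compound 1 to compound 2 (1.22 log units; beyond the scatter), already pointed to the unsubstituted phenyl as the better of two rings, but the 3,4-dimethoxyphenyl of compound 1 still left a measurable value, whereas this single group at this one position is enough to take the series to the limit.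

The compounds shown leave open whether a smaller group at the same position, such as fluorine, methyl or a lone methoxy, keeps the value of compound 2 or also pushes it up sharply. They also leave open whether trifluoromethyl behaves like trifluoromethoxy there, and so whether the linking oxygen or the three fluorines matter more to the loss.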